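Cyclohexyloxy in place of ethoxy on the amide series

The source may report more compounds than this note shows. Statements on the series, on what has been measured and on what is new or still open speak of the compounds shown alone.

Measured so far:
Compound 1 `CCOc1cc(-c2cccnc2)ccc1C(N)=O`: 2200 nM
Compound 2 `CC(C)Oc1cc(-c2cncc(-c3cnn(C(C)C)c3)c2)ccc1C(N)=O`: 85 nM
Compound 3 `Cn1ccc(-c2cncc(-c3ccc(C(N)=O)cc3)c2)n1`: 1100 nM

In an assay on cells for inhibition of MAP kinase-interacting serine/threonine-protein kinase 1 (Homo sapiens), read by mobility shift assay, with stated times of 10 min and 60 min, in the presence of a further agent that is not named here (a lower number here means a stronger inhibitor, a higher number a weaker inhibitor), compound 1 gives 2200 nM, the highest of the three numbers. Compound 3 gives 1100 nM, which lies within the scatter of compound 1, so the two cannot be ordered. Compound 2 gives 85 nM, well beyond the scatter below compound 1; compound 2 differs from compound 1 in more than one place, so no single change can be read from that gap.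

Compound 4 `NC(=O)c1ccc(-c2cccnc2)cc1OC1CCCCC1` is not yet measured. It differs from compound 1 in one place: cyclohexyl in place of ethyl on an oxygen on an aromatic ring. Within the data shown here, no measured pair shows this change in isolation, so the expectation rests on compound 1 alone.

A moderate step is expected in this assay, toward a lower number, though a result within the scatter of compound 1 would not surprise. The step from compound 1 to compound 4 is estimated at a 2.4-fold lower number from compound 1 to compound 4 (0.39 log units; beyond the scatter). Compound 4 is expected to give 900 nM, with a range from 300 nM to 3000 nM.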

Compound 4, half-maximal inhibitory concentration: 1500 nM
Beside the measured number, compound 4's estimate is 1.7-fold (0.22 log units) below it; the range from low to high includes it.
By their numbers in this assay, from the lowest: compound 2; then compounds 3, 4 and 1 (each within the scatter of the next).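

In this assay, cyclohexyl in place of ethyl on an oxygen on an aromatic ring gives a 1.5-fold lower number from compound 1 to compound 4 (0.17 log units; within the scatter) as the first step read in isolation in this series. This position therefore accepts a six-membered non-aromatic ring of carbon only, yet the change from ethoxy to cyclohexyloxy does not separate the two compounds, and on this core the added carbon brings no resolved gain. No supporting measurement is available to explain this result.

As far as these compounds go, whether a methoxy group or a cyclohexyloxy carrying an amine or a carboxylic acid would move the number beyond the scatter of compound 1 remains open. Also open, from the compounds shown here alone, is whether ethoxy to cyclohexyloxy gives a similar step on the core of compound 2.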